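Trifluoromethyl for Trifluoromethoxy: Tolerance in Liver Cells

The source may report more compounds than this note shows. Statements on the series, on what has been measured and on what is new or still open speak of the compounds shown alone.

Compound 1 `CN1CCN(CCNCc2cn(-c3ccc(C(F)(F)F)cc3)nc2-c2ccc(OC(F)(F)F)cc2)CC1` gives 3000 nM in an ADME assay on Huh-7 cells (Homo sapiens) for cytotoxicity; a higher number here means that more compound is tolerated, a lower number that less compound is tolerated. Compound 2 `CCCN1CCC(CNCc2cn(-c3ccc([N+](=O)[O-])cc3)nc2-c2ccc(OC(F)(F)F)cc2)CC1` gives 18000 nM in this assay. Compound 3 `CN1CCN(CCNCc2cn(-c3ccc(C(F)(F)F)cc3)nc2-c2ccc(C(F)(F)F)cc2)CC1` gives 1500 nM in this assay.

Compound 1 and compound 3 differ in one place: trifluoromethyl in place of trifluoromethoxy on an aromatic carbon. This change gave a 2.0-fold lower number from compound 1 to compound 3 (0.30 log units; within the scatter). Compound 4 `CCCN1CCC(CNCc2cn(-c3ccc([N+](=O)[O-])cc3)nc2-c2ccc(C(F)(F)F)cc2)CC1` has not yet been measured; it stands to compound 2 as compound 3 stands to compound 1: trifluoromethyl in place of trifluoromethoxy on an aromatic carbon. The difference between the cores of compound 1 and compound 2 is not broken down here, but the place of the change reads the same for both pairs, so it is the same change. A step of about the same small size is expected from compound 2 to compound 4, namely a 1.6-fold lower number from compound 2 to compound 4 (0.21 log units; within the scatter), because the matching step gave a 2.0-fold lower number from compound 1 to compound 3 (0.30 log units; within the scatter). Compound 4 is therefore estimated at 11000 nM, with a range from 4000 nM to 30000 nM.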

Compound 4, half-maximal cytotoxic concentration: 2300 nM
The estimate for compound 4 lay 4.8-fold (0.68 log units) above the measured number; the whole stated range lies above it.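

The size of this change did not carry over from one core to the other in this assay. On the core of compound 2, trifluoromethyl in place of trifluoromethoxy gave a 7.8-fold lower number from compound 2 to compound 4 (0.89 log units; beyond the scatter), and the two cores disagree on the size of the step: the same change on two cores in this assay, a 2.0-fold lower number (0.30 log units; within the scatter) from compound 1 to compound 3 and a 7.8-fold lower number (0.89 log units; beyond the scatter) from compound 2 to compound 4, 3.9-fold (0.59 log units) apart, beyond the scatter of two such steps. This shows that a step measured on one core cannot simply be copied to another in this series, but two pairs do not show which part of the core sets the size, since the cores of compound 1 and compound 2 differ in more than one place.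

The compounds shown leave open whether the nitro group or the propyl chain goes with the larger step. They also leave open how a nitrile or a chlorine in the same place would compare.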